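This account rests on a few compounds, and the source may have more. Where it says the series, first, only, none or still open, it means among the compounds named here.

Measured so far:
compound 1 `CCn1ccc(N2C[C@H](CO)OC2=O)c1` — 3 nM
compound 2 `C=CCn1ccc(N2C[C@H](CO)OC2=O)c1` — 350 nM
compound 3 `COC[C@H]1CN(c2ccn(C)c2)C(=O)O1` — 300 nM

In an assay for inhibition of Amine oxidase [flavin-containing] A (Bos taurus), read by fluorescence, with a stated time of 30 min (a higher number here means a weaker inhibitor, a lower number a stronger inhibitor), compound 3 gives 300 nM, close to compound 2, and well weaker than compound 1, the only one of the three that binds tightly. Compound 4 `C=CCn1ccc(N2C[C@H](COC)OC2=O)c1` differs from compound 3 by vinyl in place of hydrogen on a saturated chain carbon bound to an aromatic nitrogen, read one bond further out as methyl to allyl. For the measured compounds named here, the one measured step of the same kind is a 120-fold higher number from compound 1 to compound 2 (2.07 log units; beyond the scatter), a large loss in this assay. Compound 3 already stands at a weak number, so the same loss placed on it would run toward the edge of this assay. A large rise in this assay is therefore expected for compound 4, of roughly a 40-fold higher number from compound 3 to compound 4 (1.60 log units; beyond the scatter). The expected inhibition constant of compound 4 is 12000 nM, with a range from 2000 nM to 60000 nM.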

Compound 4, inhibition constant: 1 nM
For compound 4 the middle estimate is 12000-fold (4.08 log units) above the measured one; measured number below the stated range.
By their numbers in this assay, from the lowest: compound 4; then compound 1; then compounds 3 and 2 (each within the scatter of the next).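

In this assay, vinyl in place of hydrogen on a saturated chain carbon bound to an aromatic nitrogen gives a 300-fold lower number from compound 3 to compound 4 (2.48 log units; beyond the scatter) and runs opposite to a 120-fold higher number from compound 1 to compound 2 (2.07 log units; beyond the scatter) so vinyl at this position has no single direction across the series. With the allyl group held, methyl in place of hydrogen on an oxygen on a saturated carbon gives a 350-fold lower number from compound 2 to compound 4 (2.54 log units; beyond the scatter) so the two places do not act independently here. No measurement shown accounts for this reversal.

Open, going by these compounds, is whether the low numbers persist with a longer chain, such as propyl, on the aromatic nitrogen. Also open, on these data alone, is whether an ethyl group on that oxygen matches methyl.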